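The compounds below may be only part of what the source reports. "The series", "measured", "known", "first", "only" and "open" are said of these compounds alone.

The series shares a core in which an aryloxyacetamide-type carbonyl carries a substituted nitrogen; the compounds differ in what stands on that nitrogen and on the chain. Compound 1 `CCN(C(=O)COc1ccc(C)cc1)C(C)c1cccs1` gives "not active" (no number reported) in an assay on HEK293 cells for agonist activity at transient receptor potential cation channel subfamily M member 8 (Homo sapiens), read by fluorescence and calcium flux, with a stated time of 15 min (a lower number here means that less compound is needed, a higher number that more compound is needed for the effect), so no number is available for it. Compound 2 `CCN(Cc1cccs1)C(=O)C(C)Oc1ccc(C)cc1` gives 889 nM in this assay. Compound 3 `Cc1ccc(OCC(=O)N(Cc2cccs2)C(C)(C)C)cc1` gives 11000 nM in this assay, the highest of the two reported numbers; the gap between compound 3 and compound 2 lies beyond the scatter, so compound 3 needs clearly more compound than compound 2 for the same effect.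

Compound 4 `Cc1ccc(OCC(=O)N(Cc2cccs2)c2ccon2)cc1` is the next structure to be tested and differs from compound 3 in one place: 1,2-oxazol-3-yl in place of tert-butyl on an amide-type nitrogen. Within the data shown here, no step between two measured compounds shows what such a change does on the amide-type nitrogen, so any expectation rests on the weak standing of compound 3 alone. Compound 4 is expected to show a moderate step down from compound 3, a 2.2-fold lower number from compound 3 to compound 4 (0.34 log units; beyond the scatter) in this assay, though a result within the scatter would not be surprising given how little the measured compounds say about this position. The estimate for compound 4 in this assay is 5000 nM, with a range from 1000 nM to 25000 nM.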

Compound 4, half-maximal effective concentration: 2 nM
Beside the measured number, compound 4's estimate is 2500-fold (3.40 log units) above it; the measured number lies below the stated range.
By their numbers in this assay, from the lowest: compound 4; then compound 2; then compound 3.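

With a step of a 5500-fold lower number from compound 3 to compound 4 (3.74 log units; beyond the scatter) in this assay, the series gives its first one-place reading at the amide-type nitrogen, whose other neighbours are the carbonyl carbon and a saturated chain carbon, and it shows that the group standing there can shift the number very strongly. The change is not a single feature, however: tert-butyl, with no ring and 0 hydrogen-bond acceptors, leaves, and 1,2-oxazol-3-yl, with one five-membered aromatic ring holding 2 hetero atoms and with 2 hydrogen-bond acceptors, enters, so the step measures the whole exchange. No measurement available here accounts for the size of this step.

The compounds shown do not separate the contribution of the ring from that of its hetero atoms, and they do not show how a longer chain, an amine or a carboxylic acid on this nitrogen would read. As far as these compounds go, it also remains open whether 1,2-oxazol-3-yl would give a step of similar size in place of the ethyl group on the nitrogen of compound 2, where the chain also differs.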